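The compounds below may be only part of what the source reports. "The series", "measured", "known", "first", "only" and "open" are said of these compounds alone.

Working notes on the series in a functional assay on U-251 cells (Homo sapiens) for inhibition, read by sulforhodamine B assay, with a stated time of 48 h, tested at 10 uM; on this read-out higher numbers stand for more inhibition at the one concentration tested (going by the name of the read-out) and lower numbers for less inhibition.

For the measured compounds named here, compound 1 `COc1ccc(-c2cn3ccnc3c(-c3ccc4ncn(C5CCCCC5)c4c3)n2)cc1` gives 80.9% in this assay, the highest of the three numbers so far. Compound 2 `Fc1ccc(-c2cn3ccnc3c(-c3ccc4ncn(C5CCCCC5)c4c3)n2)cc1` gives 7.94%; the change from compound 1 is fluoro in place of methoxy on an aromatic carbon and the step is a number 73 percentage points lower from compound 1 to compound 2 (beyond the scatter). Compound 3 `COc1ccccc1-c1cn2ccnc2c(-c2ccc3ncn(C4CCCCC4)c3c2)n1` gives 21%; the two cores differ as 2-methoxyphenyl in place of 4-methoxyphenyl on an aromatic carbon, and the step is a number 59.9 percentage points lower from compound 1 to compound 3 (beyond the scatter). From compound 2 to compound 3 the step is a number 13.1 percentage points higher from compound 2 to compound 3 (beyond the scatter).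

Compound 4 `Fc1ccccc1-c1cn2ccnc2c(-c2ccc3ncn(C4CCCCC4)c3c2)n1` has not yet been measured in this assay. It differs from compound 3 as fluoro in place of methoxy on an aromatic carbon. Going by the values given here, this is the same kind of change as the one from compound 1 to compound 2, not the same change: there the fluoro sits para to a large group, here it sits ortho to a large group. Among the compounds with values here, the one measured instance of this kind of change is a number 73 percentage points lower from compound 1 to compound 2 (beyond the scatter), a large drop.

Within the data shown here, compound 3 starts much lower than compound 1, so a drop of that full size cannot repeat; the expectation is a step of a number 13 percentage points lower from compound 3 to compound 4 (beyond the scatter) from compound 3 to compound 4, resting on the single measured step of a number 73 percentage points lower from compound 1 to compound 2 (beyond the scatter) and on the low starting value of compound 3, 21%. Compound 4 is estimated to give 8%, expected to lie between 0% and 25%.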

Compound 4, a percentage reported as inhibition, at one concentration (the size of the read-out at that concentration, not a potency): 11.4%
Compound 4: middle estimate off by 3.4 percentage points, on the low side; measured number inside the range.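

Carried from the core of compound 1 to the core of compound 3 in this assay, fluoro in place of methoxy does not keep the size of its step: the same change on two cores in this assay, a number 73 percentage points lower (beyond the scatter) from compound 1 to compound 2 and a number 9.6 percentage points lower (within the scatter) from compound 3 to compound 4, 63.4 percentage points apart, beyond the scatter of two such steps. On the second core the step is a number 9.6 percentage points lower from compound 3 to compound 4 (within the scatter), so methoxy and fluoro cannot be told apart there, and moving the fluoro gives a number 3.5 percentage points higher from compound 2 to compound 4 (within the scatter), which also leaves 2-fluorophenyl and 4-fluorophenyl unresolved, while the step that changes both the group and its place is a number 69.5 percentage points lower from compound 1 to compound 4 (beyond the scatter). This shows that the large drop seen on the core of compound 1 cannot be assumed on another core, but two pairs give no rule for further cores and do not show why the two steps differ.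

The compounds shown leave open how an amine, a carboxylic acid or a longer chain such as ethoxy would read in place of the methoxy of 4-methoxyphenyl, and so whether the high number of compound 1 belongs to methoxy alone. With one concentration per compound, the read-out also leaves open how these numbers would translate into potency.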